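Methoxymethoxy replaces methoxycarbonyl on compound 2

The compounds below may be only part of what the source reports. "The series", "measured", "known", "first", "only" and "open" are said of these compounds alone.

Of the compounds shown here, two have been tested so far in an ADME assay on HEp-2 cells (Homo sapiens) for cytotoxicity, read by MTT assay, with a stated time of 72 h; a lower number here means a stronger inhibitor, a higher number a weaker inhibitor: compound 1 `COc1cc(C2=C(c3cc(C)c(OC)c(C)c3)C(O)CC2=O)cc(OC)c1OC` and compound 2 `COC(=O)c1cc(C2=C(c3cc(OC)c(OC)c(OC)c3)C(=O)CC2O[SiH2]C(C)(C)C)ccc1OC`. Compound 1 gives > 100 ug/mL, which is a limit of the assay and not a number. Compound 2 gives > 100 ug/mL, which is also a limit. Compound 2 therefore stands at the limit of > 100 ug/mL in this assay, at which 2 of the 2 values shown sit, and no actual number is available for it.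

Compound 3 `COCOc1cc(C2=C(c3cc(OC)c(OC)c(OC)c3)C(=O)CC2O[SiH2]C(C)(C)C)ccc1OC` differs from compound 2 in one group: methoxymethoxy in place of methoxycarbonyl on an aromatic carbon. This places methoxymethoxy in place of methoxycarbonyl on an aromatic carbon, ortho to a methoxy group. For the measured compounds named here, no measured pair shows what this swap does, so any expectation is loose: a modest move towards a lower number, or none beyond the scatter. The estimated step is an at least 1.2-fold lower number from compound 2 to compound 3 (0.09 log units; that floor lies within the scatter). For compound 3 the expected value is 80 ug/mL, within an estimated range of 15 ug/mL to 150 ug/mL.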

Compound 3, half-maximal inhibitory concentration: 12 ug/mL
Estimate against measurement, compound 3: 6.7-fold (0.82 log units) above; measured number outside the range, below it.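

In this assay, putting methoxymethoxy in place of methoxycarbonyl on this aromatic carbon, ortho to a methoxy group, brings an at least 8.3-fold lower number from compound 2 to compound 3 (0.92 log units; beyond the scatter). The two groups have the same counts of heavy atoms and hydrogen-bond acceptors, yet only the group that leaves has a double bond outside the ring, so those shared counts alone do not settle the reading at this position. The true size of the step remains unknown because compound 2 sits at a limit of the assay and not at a number: the limit of > 100 ug/mL in this assay, at which 2 of the 3 values shown sit.

The compounds shown leave open whether the lower number comes from gaining methoxymethoxy or from losing methoxycarbonyl, a question that a hydroxyl group or an amine at this carbon could help to separate. They also leave open whether the same swap would give a similar step on the core of compound 1.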